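The source may report more compounds than this note shows. Statements on the series, on what has been measured and on what is new or still open speak of the compounds shown alone.

In a functional assay on the whole organism for agonist activity, with Mus musculus as the target (on this read-out higher numbers stand for an effect only at larger amounts of compound and lower numbers for an effect already at smaller amounts), compound 2 `CN(C)C(=O)N(C)CC#CCN1CCCC1` stands at > 10 mg/kg as a limit, not a number. Compound 3 `CN(C)C(=O)N(C)CC#CCn1ccnc1` has 1H-imidazol-1-yl in place of pyrrolidin-1-yl on a saturated chain carbon bound to a triple-bonded carbon. Compound 1 `CC(=O)N(C)CC#CCn1ccnc1` also carries 1H-imidazol-1-yl and gives 1.4 mg/kg in this assay as a real number, which points towards smaller doses. The expected step in this assay (an at least 2.5-fold lower number from compound 2 to compound 3 (0.39 log units; beyond the scatter)) is therefore a moderate one in that direction. Compound 3 is estimated at 4 mg/kg and expected to fall between 1.2 mg/kg and 13 mg/kg.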

Compound 3, dose for half-maximal effect: > 100 mg/kg
Compound 3: no number, only a limit (the forecaster's own chance of this, stated with the estimate: 30%); middle value at least 25-fold (1.39 log units) from the limit.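

With 1H-imidazol-1-yl held fixed, dimethylamino in place of methyl on a carbonyl carbon brings an at least 71-fold higher number from compound 1 to compound 3 (1.85 log units; beyond the scatter) in this assay. So 1H-imidazol-1-yl on the saturated chain carbon does not by itself secure an effect at small doses, and the group on the carbonyl carbon matters as well. The step from compound 2 to compound 3 cannot be read, as both compounds carry only limits.

Open, going by these compounds, is how pyrrolidin-1-yl would behave with methyl on the carbonyl carbon. Also open, on these data alone, is how an ethyl or a methoxy group on that carbon would read.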